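Sulfonamide to benzylic amine on a shared indole core

The source may hold more compounds than are shown below. What is called first, only, known or untested is meant among the compounds shown, and "the series" means these compounds.

Measured compounds:
compound 1 `O=S(=O)(NCC1CCN(CCCc2c[nH]c3ccc(-n4cnnc4)cc23)CC1)c1ccccc1` 6.2 nM
compound 2 `CN(C1CCN(CCCc2c[nH]c3ccc(-n4cnnc4)cc23)CC1)S(=O)(=O)c1ccccc1` 1.5 nM

Going by the values given here, in an assay on CHO cells for displacement of a labelled ligand from 5-hydroxytryptamine receptor 1D (Homo sapiens) (a lower number here means a stronger inhibitor, a higher number a weaker inhibitor), compound 1 gives the higher of the two numbers; the single step of a 4.1-fold lower number from compound 1 to compound 2 (0.62 log units; beyond the scatter) changes only the linker to the sulfonamide nitrogen. Compound 3 `CC(=O)Nc1ccc([C@H](C)NCC2CCN(CCCc3c[nH]c4ccc(-n5cnnc5)cc34)CC2)cc1` is not yet measured. It differs from compound 1 in 1-(4-acetamidophenyl)ethyl in place of phenylsulfonyl on an amine nitrogen. Among the compounds with values here, no measured step touches the phenylsulfonyl group itself, so the direction of change is open. Compound 3 is expected to remain in the same potency range, estimated at 10 nM (range 2 nM to 50 nM), a step of a 1.6-fold higher number from compound 1 to compound 3 (0.21 log units; within the scatter) that is expected to stay near the scatter.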

Compound 3, half-maximal inhibitory concentration: 0.6 nM
For compound 3 the middle estimate is 17-fold (1.22 log units) above the measured one; measured number outside the range, below it.
By their numbers in this assay, from the lowest: compound 3; then compound 2; then compound 1.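

In this assay, the step of a 10-fold lower number from compound 1 to compound 3 (1.01 log units; beyond the scatter) shows that phenylsulfonyl is not needed on this amine nitrogen: 1-(4-acetamidophenyl)ethyl takes its place and gives a stronger inhibitor. Going by these compounds alone, the earlier step altered only the linker and kept the sulfonyl group, so this is the first change to the group itself. No available evidence bears on the gain.

On these data alone, the acetamido group, the methyl and the defined stereocentre entered together, so their separate contributions remain open. Whether a plain benzyl group would do the same is also unknown.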